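The compounds below may be only part of what the source reports. "The series", "measured", "known", "first", "only" and "open" are said of these compounds alone.

Measured so far:
- compound 1 `Cc1cc(C)n(CCOC2CC(=O)Nc3c2c(C)nn3-c2ncnc3nc[nH]c23)n1`, a functional assay on HEK293 cells for agonist activity at G-protein coupled receptor 39 (Homo sapiens), read by scintillation proximity assay and inositol phosphate accumulation, with a stated time of 75 min, in the presence of a further agent that is not named here; a lower number here means that less compound is needed, a higher number that more compound is needed for the effect: 16 nM
- compound 2 `Cc1nn(-c2ncnc3nc[nH]c23)c2c1C(OC(=O)c1ccc(F)cc1)CC(=O)N2`, this assay: 4 nM
- compound 3 `CCCCCCCCOC1CC(=O)Nc2c1c(C)nn2-c1ncnc2nc[nH]c12`, this assay: 8 nM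

Compound 3 has the second highest of the three numbers; one of its two gaps is a 2.0-fold higher number from compound 2 to compound 3 (0.30 log units; within the scatter), and the other is a 2.0-fold lower number from compound 1 to compound 3 (0.30 log units; within the scatter), both within the scatter. Compound 4 `Cc1nn(-c2ncnc3nc[nH]c23)c2c1C(OCc1ccc(F)cc1)CC(=O)N2` differs from compound 3 by 4-fluorophenyl in place of heptyl on a saturated chain carbon bound to an oxygen on a saturated carbon. The step bearing most directly on it is a 2.0-fold higher number from compound 2 to compound 3 (0.30 log units; within the scatter), within the scatter; the larger step in the set is a 4.0-fold lower number from compound 1 to compound 2 (0.60 log units; beyond the scatter). Compound 4 carries a 4-fluorophenyl ring on the ether side chain, as compound 2 does, so a small step, near the edge of the scatter, toward a lower number is expected: a 1.6-fold lower number from compound 3 to compound 4 (0.20 log units; within the scatter). For compound 4 in this assay the estimate is 5 nM, ranging from 2 nM to 15 nM.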

Compound 4, half-maximal effective concentration: 1 nM
The estimate for compound 4 lay 5.0-fold (0.70 log units) above the measured number; measured number outside the range, below it.
By their numbers in this assay, from the lowest: compound 4; then compounds 2, 3 and 1 (each within the scatter of the next, the first and the last beyond it).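

On the oxygen on a saturated carbon, 4-fluorobenzyl sets itself apart beyond the scatter: replacing the octyl of compound 3 gives an 8.0-fold lower number from compound 3 to compound 4 (0.90 log units; beyond the scatter), and replacing the (4-fluorophenyl)carbonyl of compound 2 gives a 4.0-fold lower number from compound 2 to compound 4 (0.60 log units; beyond the scatter), so the same 4-fluorophenyl ring reads differently depending on how it is attached. Against the pyrazole-bearing chain the step is the largest in the set, a 16-fold lower number from compound 1 to compound 4 (1.20 log units; beyond the scatter). Nothing available explains these steps.

Open, going by these compounds, is whether the fluorine contributes, which an unsubstituted benzyl would test, and whether a benzyl carrying an amine or a carboxylic acid holds this number.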